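Plasma protein binding in the urea series: compound 4

The compounds below may be only part of what the source reports. "The series", "measured", "known", "first", "only" and "open" are said of these compounds alone.

Measured so far in an ADME assay on a cell-free system (plasma, Homo sapiens) for protein binding:
compound 1 `CNc1nccc(N2CC[C@H](NC(=O)Nc3ccc(Cl)c(C(F)(F)F)c3)C2)n1`: 99.8%
compound 2 `CNc1nccc(N2CC[C@H](NC(=O)Nc3ccc(CN(C)C)c(C(F)(F)F)c3)C2)n1`: 94.3%
compound 3 `CNc1nccc(N2CC[C@H](NC(=O)Nc3ccc(C)c(Cl)c3)C2)n1`: 99.3%

Compound 2 holds the highest unbound fraction of the three; compound 3 gives 99.3% and compound 1 gives 99.8%, both well beyond the scatter from it. Compound 4 `CNc1nccc(N2CC[C@H](NC(=O)Nc3ccc(CN4CCN(C)CC4)c(C(F)(F)F)c3)C2)n1` differs from compound 2 by 4-methylpiperazin-1-yl in place of dimethylamino on a saturated chain carbon bound to an aromatic carbon. Among the measured compounds shown here, the one step that bears on this part of the structure is a 29-fold higher unbound fraction from compound 1 to compound 2 (1.45 log units; beyond the scatter), but that step introduced the (dimethylamino)methyl group rather than exchanging the amine within it; no measured pair covers an exchange of one amine for another. The expectation for this assay is therefore no step beyond the scatter, a 1.2-fold higher unbound fraction from compound 2 to compound 4 (0.09 log units; within the scatter). Compound 4 is estimated at 93%, within the range 85% to 97.5%.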

Compound 4, plasma protein binding: 87.6%
Compound 4: the middle estimate sits 1.8-fold (0.25 log units) (unbound fraction) below what was measured; the measured number falls inside the stated range.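

In this assay, the amine within the side chain is not interchangeable: 4-methylpiperazin-1-yl in place of dimethylamino on a saturated chain carbon bound to an aromatic carbon gives a 2.2-fold higher unbound fraction from compound 2 to compound 4 (0.34 log units; beyond the scatter). Measured against chloro, the (4-methylpiperazin-1-yl)methyl group gives a 62-fold higher unbound fraction from compound 1 to compound 4 (1.79 log units; beyond the scatter), so the size of the gain depends on which amine is carried. No available evidence accounts for this difference. Still open, as far as these compounds go, is whether the gain follows the six-membered ring or its methylated nitrogen; morpholin-4-yl on the same carbon would separate the two.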